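A methoxy swap on the carbon double-bonded to nitrogen

The compounds below may be only part of what the source reports. "The series", "measured", "known", "first", "only" and "open" are said of these compounds alone.

Measured in a functional assay on K562/A02 cells (Homo sapiens) for antiproliferative activity, read by MTT assay; on this read-out higher numbers stand for weaker inhibition and lower numbers for stronger inhibition:
Compound 1 `Cc1ccc(/C(=N/NC(=S)NCCCCCC(=O)NO)c2ccccc2)cc1`: 3150 nM
Compound 2 `C/C(=N\NC(=S)NCCCCCC(=O)NO)c1ccc(F)cc1`: 1020 nM

For the measured compounds named here, of these two numbers, the one for compound 1 is the higher, which makes it the weaker inhibitor of the pair. Compound 2 gives the lower number, and the gap between the two lies beyond the usual scatter. The two compounds differ in more than one place, however, so their gap does not isolate the effect of any single change.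

Compound 3 `COc1ccccc1/C(=N/NC(=S)NCCCCCC(=O)NO)c1ccccc1` has not yet been measured. It keeps the core of compound 1 but carries 2-methoxyphenyl in place of 4-methylphenyl on a carbon with a double bond to nitrogen. Going by the values given here, no measured pair shows what this swap does. The closest guide is compound 1 itself at 3150 nM, and no change beyond the scatter is expected in this assay. The expected move is small, a 1.1-fold lower number from compound 1 to compound 3 (0.05 log units; within the scatter), and its direction is uncertain. For compound 3 the estimated value is 2800 nM, with an expected range of 1000 nM to 7500 nM.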

Compound 3, half-maximal inhibitory concentration: 2910 nM
Estimate against measurement, compound 3: 1.0-fold (0.02 log units) below; measured number inside the range.
By their numbers in this assay, from the lowest: compound 2; then compounds 3 and 1 (each within the scatter of the next).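

In this assay, 2-methoxyphenyl in place of 4-methylphenyl on a carbon with a double bond to nitrogen gives a 1.1-fold lower number from compound 1 to compound 3 (0.03 log units; within the scatter), and this is the first single change at this position that can be read from the compounds shown. The entering group brings an oxygen and a hydrogen-bond acceptor that 4-methylphenyl does not have, yet the step stays within the scatter, so for this one pair the position accepts the exchange without a measurable shift in antiproliferative read-out. No measurement available here bears on why the two groups read alike.

This single pair cannot show whether the result holds for other groups on that carbon, such as an amine, a carboxylic acid or a plain 4-methoxyphenyl, any of which might move the number beyond the scatter. Compound 2 differs from compound 1 and compound 3 in more than one place, so its lower number leaves open which of its differences matters.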